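The source may report more compounds than this note shows. Statements on the series, on what has been measured and on what is new or still open speak of the compounds shown alone.

Compounds measured so far:
compound 1 `COC(=O)c1ccc(/C=C(\C)c2ccc3c(c2)C(C)(C)CCS3)cc1` with 620 nM
compound 2 `CC(/C=C/C=C(\C)c1ccc2c(c1)C(C)(C)CCS2)=C\C(=O)O` with 1400 nM
compound 3 `C/C(=C\c1ccc(C(=O)O)cc1)c1ccc2c(c1)C(C)(C)CCO2` with 1100 nM

In an assay on CV-1 cells for activation of retinoic acid receptor alpha (Homo sapiens) (on this read-out higher numbers stand for an effect only at larger amounts of compound and lower numbers for an effect already at smaller amounts), the three numbers lie close together: compound 3 is separated from compound 2 and from compound 1 by gaps that both fall within the usual scatter of this assay, so nothing in these data sets compound 3 apart from the other two. Compound 4 `COC(=O)c1ccc(/C=C(\C)c2ccc3c(c2)C(C)(C)CCO3)cc1` has not yet been measured. It differs from compound 3 by methyl in place of hydrogen on an oxygen next to a carbonyl group, which puts a methoxycarbonyl where compound 3 carries a carboxy group. Within the data shown here, no measured pair isolates this change, and the ester compound 1 and the acid compound 3 also differ in their cores, so their values cannot be read as a step. The expected step of a 1.2-fold lower number from compound 3 to compound 4 (0.09 log units; within the scatter) is therefore small, no larger than the scatter, in no firm direction. Compound 4 is estimated at 900 nM, within 400 nM to 2000 nM.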

Compound 4, half-maximal effective concentration: 1100 nM
Compound 4: middle estimate off by 1.2-fold (0.09 log units), on the low side; low and high end bracket the measured number.
By their numbers in this assay, from the lowest: compounds 1, 3, 4 and 2 (each within the scatter of the next, the first and the last beyond it).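

In this assay, among these compounds, the change of hydrogen to methyl on an oxygen next to a carbonyl group, which turns carboxy into methoxycarbonyl, gives no change at the digits printed from compound 3 to compound 4 (within the scatter) and supplies the first pair that differs in one place. On this core, the carboxylic acid and its methyl ester therefore cannot be told apart on this read-out. No available evidence bears on this result. Still open, on these data alone, is whether an ethyl ester, an amide or a hydroxymethyl group here would read the same, and whether the same change would do so on the core of compound 1.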